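This account rests on a few compounds, and the source may have more. Where it says the series, first, only, none or still open, it means among the compounds named here.

Measured in an ADME assay on HepG2 cells (Homo sapiens) for cytotoxicity, read by MTT assay, with a stated time of 48 h; on this read-out higher numbers stand for weaker inhibition and lower numbers for stronger inhibition (both readings are limits):
compound 1 `O=S(=O)(c1ccc(-c2ccc3ncnc(Nc4ccccc4)c3c2)cc1)N1CCOCC1` gives > 3000 nM (a limit)
compound 2 `O=S(=O)(c1ccc(-c2ccc3ncnc(Nc4ccc(OCc5cccc(Cl)c5)c(Cl)c4)c3c2)cc1)N1CCOCC1` gives > 15000 nM (a limit)

Compound 2 stands at > 15000 nM as a limit, so no number is available for it. The change methoxy in place of chloro on an aromatic carbon puts methoxy in place of chloro on an aromatic carbon, meta to a large group, and leads to compound 3 `COc1cccc(COc2ccc(Nc3ncnc4ccc(-c5ccc(S(=O)(=O)N6CCOCC6)cc5)cc34)cc2Cl)c1` as the next entry. For the measured compounds named here, no measured step sizes this change. The expected step that the limit leaves unreadable from compound 2 to compound 3 stays within the usual scatter, with no direction foreseen, and another limit reading is likely. Estimated for compound 3 is 16000 nM within an expected range of 7000 nM to 40000 nM on measurement.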

Compound 3, half-maximal inhibitory concentration: > 15000 nM
Compound 3 ended at the assay's limit; the forecaster's own chance of this, stated with the estimate: 75%; the middle value lies beyond the limit too.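

In this assay, compound 2 and compound 3 both end at the same limit, so no step between them can be read: the limit of > 15000 nM in this assay, at which 2 of the 3 values shown sit.

The compounds shown leave open where either true value lies, and so what methoxy in place of chloro does on this read-out.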